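Piperazine amide in place of carboxylic acid on an adenosine ligand

The source may report more compounds than this note shows. Statements on the series, on what has been measured and on what is new or still open speak of the compounds shown alone.

Compound 1 `CNC(=O)[C@H]1O[C@@H](n2cnc3c(NCc4cc(Cl)cc(Cl)c4)ncnc32)[C@H](O)[C@@H]1N`: 25 nM
Compound 2 `CNC(=O)[C@H]1O[C@@H](n2cnc3c(NCc4cc(Cl)ccc4OCC(=O)O)ncnc32)[C@H](O)[C@@H]1N`: 130 nM

Of the compounds shown here, two built on a shared core have been measured in an assay on isolated protein for binding affinity to adenosine receptor A3 (Homo sapiens); on this read-out lower numbers stand for stronger inhibition and higher numbers for weaker inhibition. Compound 1 gives 25 nM, and compound 2 gives 130 nM. Of the two numbers, that of compound 2 is the higher one, and the gap between them is beyond the scatter, so compound 2 stands as the weaker binder of the pair in this assay.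

Compound 3 `CNC(=O)[C@H]1O[C@@H](n2cnc3c(NCc4cc(Cl)ccc4OCC(=O)N4CCNCC4)ncnc32)[C@H](O)[C@@H]1N` follows compound 2 with a single change: piperazin-1-yl in place of hydroxy on a carbonyl carbon. The carboxymethoxy group of compound 2 thus becomes a ((piperazin-1-yl)carbonyl)methoxy group in compound 3.

Within the data shown here, no measured pair within this small set shows how such a change plays out, so the expectation rests on the position of compound 2 alone. The step of a 1.3-fold lower number from compound 2 to compound 3 (0.11 log units; within the scatter) is expected to be modest, and its direction is uncertain; compound 3 is estimated to remain in the neighbourhood of compound 2. For compound 3 the expected value in this assay is 100 nM, with a range from 30 nM to 400 nM.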

Compound 3, inhibition constant: 9.4 nM
Beside the measured number, compound 3's estimate is 11-fold (1.03 log units) above it; the measured number lies below the stated range.
By their numbers in this assay, from the lowest: compound 3; then compound 1; then compound 2.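

In this assay, the carbonyl carbon of the carboxymethoxy group of compound 2 turns out to be a place where the choice of group counts: piperazin-1-yl in place of hydroxy on that carbon brings a 14-fold lower number from compound 2 to compound 3 (1.14 log units; beyond the scatter), a large step and the only one in this set that isolates a single change. Before it, the set held no pair differing in one place, so nothing showed how this part of the molecule responds to substitution. The step now shows that the carboxy group is not needed at the end of this chain for binding in this assay, and that the (piperazin-1-yl)carbonyl group, with its six-membered non-aromatic ring, goes with a far lower number on the same chain.

Going by these compounds, a single step cannot separate the contributions of the amide carbonyl, the ring and the ring's free amine, so it remains open how a simple methyl amide, a morpholin-4-yl amide, an N-methylpiperazin-1-yl amide or an open-chain aminoethyl amide would compare with compound 3. Why the number falls so far also stays open, as nothing in hand bears on the cause of this step.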